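Methoxy for Chloro Tested on Two Different Cores

The compounds below may be only part of what the source reports. "The series", "measured", "known", "first", "only" and "open" are said of these compounds alone.

Compound 1 `CN1C[C@@H](c2ccc(Cl)cc2)[C@@]2(Cc3ccccc3C2=O)[C@@]12C(=O)Nc1ccccc12` and compound 2 `COc1ccc([C@@H]2CN(C)[C@]3(C(=O)Nc4ccccc43)[C@]23Cc2ccccc2C3=O)cc1` share one core. In a functional assay on RPMI18226 cells (Homo sapiens) for antiproliferative activity, read by sulforhodamine B assay, with a stated time of 48 h, tested at 10 uM (on this read-out lower numbers stand for less inhibition and higher numbers for more inhibition at the one concentration tested (going by the name of the read-out)), compound 1 gives 63.4%, while compound 2 gives 33.3%. The change between them, (methoxy in place of chloro on an aromatic carbon), produced a number 30.1 percentage points lower from compound 1 to compound 2 (beyond the scatter). Compound 3 `O=C(Nc1ccccc1)c1c(-c2ccc(Cl)cc2)cc(-c2ccccc2)nc1Nc1ccc(Cl)cc1` is built on a different core; how the two cores differ is not broken down here. In this assay compound 3 gives 53%, a number that sits between those of compound 1 and compound 2. Compound 4 `COc1ccc(Nc2nc(-c3ccccc3)cc(-c3ccc(Cl)cc3)c2C(=O)Nc2ccccc2)cc1` has not yet been measured and stands to compound 3 as compound 2 stands to compound 1, with methoxy in place of chloro on an aromatic carbon. The place of the change is described in the same words for both pairs, so it is the same change carried onto a second core. For the measured compounds named here, with only one measured pair to go on, the expected step in this assay is a number 26 percentage points lower from compound 3 to compound 4 (beyond the scatter), an estimate resting on a number 30.1 percentage points lower from compound 1 to compound 2 (beyond the scatter). Compound 4 is therefore estimated at 27% in this assay, expected to fall between 8% and 48%.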

Compound 4, a percentage reported as inhibition, at one concentration (the size of the read-out at that concentration, not a potency): 30%
Compound 4: the middle estimate sits 3 percentage points below what was measured, within the range that was stated.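

In this assay, methoxy in place of chloro gave a number 23 percentage points lower from compound 3 to compound 4 (beyond the scatter). Set beside the earlier step on the other core, the change lowers the number by a like amount on both cores: the same change on two cores in this assay, a number 30.1 percentage points lower (beyond the scatter) from compound 1 to compound 2 and a number 23 percentage points lower (beyond the scatter) from compound 3 to compound 4, 7.1 percentage points apart, within the scatter of two such steps

Within these two pairs, then, the step carried over from one core to the other in both direction and size. Two pairs read at one concentration do not show that it would hold on any further core, and they do not explain why the number falls; the change also sits in a different setting on each core, a 4-chlorophenyl group in compound 1 and a (4-chlorophenyl)amino group in compound 3.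

As far as these compounds go, it remains open how either core would respond to a hydroxyl, an amine or a fluoro group at this place. From the compounds shown here alone, it is also open whether the 4-chlorophenyl group that compound 3 and compound 4 share would answer to the same change.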